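A few compounds are considered here, and "the series" means these few. Any claim that something is new, unique, unknown or untested is made for them only; others in the source may bear on it.

Compound 1 `CC(=O)Nc1ccc(NC(=O)c2cc(Cl)ccc2O)c(Cl)c1`: "not determined" (no result reported)
Compound 2 `O=C(Nc1ccc(NCC2CC2)cc1Cl)c1cc(Cl)ccc1O`: 14400 nM

Among the measured compounds shown here, in an ADME assay on A549 cells (Homo sapiens) for cytotoxicity, read by resazurin assay, with a stated time of 48 h (a lower number here means that less compound is tolerated, a higher number that more compound is tolerated), compound 2 gives 14400 nM as the only number so far, so there is no other measured value to rank it against. Compound 3 `CN(C)c1ccc(NC(=O)c2cc(Cl)ccc2O)c(Cl)c1` carries dimethylamino in place of (cyclopropylmethyl)amino on an aromatic carbon. For the measured compounds named here, no measured step covers this kind of change, so no shift beyond the scatter is expected in this assay and no direction is favoured. The expected step is a 1.0-fold higher number from compound 2 to compound 3 (0.02 log units; within the scatter) and no larger. For compound 3 the estimated value is 15000 nM with an expected range from 5000 nM to 45000 nM for a single measurement.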

Compound 3, half-maximal cytotoxic concentration: 85100 nM
Compound 3: middle estimate off by 5.7-fold (0.75 log units), on the low side; measured number outside the range, above it.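

In this assay, among the compounds shown here, the substituent on this aromatic carbon, para to a large group, does affect the read-out: dimethylamino in place of (cyclopropylmethyl)amino gives a 5.9-fold higher number from compound 2 to compound 3 (0.77 log units; beyond the scatter) as the first measured step. The change removes the three-membered ring and the hydrogen-bond donor together, so a single step cannot separate them. Nothing available explains the shift. Open, from the compounds shown here alone, is whether a primary amine or methylamino at this position would follow dimethylamino. A longer chain such as n-butylamino would show whether the ring itself matters.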